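The compounds below may be only part of what the source reports. "The series", "measured", "known", "first", "only" and "open" are said of these compounds alone.

Going by the values given here, in an ADME assay on microsomes from liver (Homo sapiens) for metabolic stability, read by LC-MS, using NADPH, with a stated time of 30 min, tested at 0.1 uM (a higher number here means that more of the compound is left, a lower number that less of the compound is left), compound 1 (`Cc1cc(C#N)cnc1C(=O)Nc1ccc(F)c([C@]2(C)C=C(CF)OC(N)=N2)c1`) gives 63%, while compound 2 (`C[C@@]1(c2cc(NC(=O)c3coc(C(F)F)n3)ccc2F)C=C(CF)OC(N)=N1`) gives 84%, the higher of the two numbers measured so far. Compound 3 (`C[C@@]1(c2cc(NC(=O)c3cnc(C(F)F)cn3)ccc2F)C=C(CF)OC(N)=N1`) differs from compound 2 at one place, on a carbonyl carbon whose other neighbour is an amide-type nitrogen: 5-(difluoromethyl)pyrazin-2-yl in place of 2-(difluoromethyl)-1,3-oxazol-4-yl on a carbonyl carbon. Among the compounds with values here, only one measured step bears on this place: a number 21 percentage points higher from compound 1 to compound 2 (beyond the scatter), with 2-(difluoromethyl)-1,3-oxazol-4-yl in place of 5-cyano-3-methylpyridin-2-yl. That step shows that this place can move the number, but it does not test 5-(difluoromethyl)pyrazin-2-yl itself. The new group keeps the difluoromethyl of the group it replaces, so only a small shift is expected in this assay, slightly downward from the top value of 84% held by compound 2. The expected change is a number 8 percentage points lower from compound 2 to compound 3 (within the scatter). For compound 3 the estimated value is 76%, with an expected range of 60% to 90%.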

Compound 3, percent of the compound remaining: 84%
For compound 3 the middle estimate is 8 percentage points below the measured one; the range from low to high includes it.
By their numbers in this assay, from the lowest: compound 1; then compounds 2 and 3 (each within the scatter of the next).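

In this assay, exchanging the five-membered 2-(difluoromethyl)-1,3-oxazol-4-yl for the six-membered 5-(difluoromethyl)pyrazin-2-yl on the carbonyl carbon gives no change at the digits printed from compound 2 to compound 3 (within the scatter), so at this place the ring can change without a shift beyond the scatter. Replacing 5-cyano-3-methylpyridin-2-yl with the pyrazinyl group gives a number 21 percentage points higher from compound 1 to compound 3 (beyond the scatter), which means that two different rings carrying difluoromethyl now stand clear of compound 1. Nothing available here explains why the oxazolyl and pyrazinyl groups read alike.

Going by these compounds, whether the difluoromethyl group itself matters remains open: compound 2 and compound 3 both carry it, and compound 1 differs in the whole ring. A 5-methylpyrazin-2-yl or 5-(trifluoromethyl)pyrazin-2-yl group at this place would separate the contribution of that substituent from that of the ring.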